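The compounds below may be only part of what the source reports. "The series", "measured", "known", "first", "only" and "open" are said of these compounds alone.

Measured compounds:
compound 1, `O=C(OCc1ccccc1)N1CCN(C(=S)SCc2cn(Cc3ccc(Cl)cc3)nn2)CC1`, > 128000 nM
compound 2, `CC(C)(C)OC(=O)N1CCN(C(=S)SCc2cn(Cc3ccc(Cl)c(Cl)c3)nn2)CC1`, > 128000 nM

In a functional assay on PC-3 cells (Homo sapiens) for inhibition, read by MTT assay, with a stated time of 72 h (on this read-out lower numbers stand for stronger inhibition and higher numbers for weaker inhibition), compound 1 gives > 128000 nM, which is a limit of the assay and not a number. In this assay compound 2 gives > 128000 nM, again a limit rather than a number. For the measured compounds named here, compound 2 therefore stands nowhere that can be ranked: both values shown sit at the limit of > 128000 nM in this assay, at which 2 of the 2 values shown sit, and there is no measured step between compound 1 and compound 2, since they differ in more than one place.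

The step considered leads from compound 2 to compound 3, `CC(C)(C)OC(=O)N1CCN(C(=S)SCc2cn(Cc3ccc(Cl)cc3)nn2)CC1`, which is not yet measured. The change is hydrogen in place of chloro on an aromatic carbon, in words hydrogen in place of chloro on an aromatic carbon. Going by the values given here, no measured step exists to rest on, and with both known values sitting at the limit, the step from compound 2 to compound 3 is expected to be none beyond the scatter, as a step that the limit leaves unreadable from compound 2 to compound 3 expresses. Compound 3 is thus estimated at 150000 nM in this assay, with a range from 40000 nM to 500000 nM, most likely reported again as a limit.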

Compound 3, half-maximal inhibitory concentration: > 128000 nM
Compound 3: only a limit was reported; the forecaster's own chance of this, stated with the estimate: 80%; the middle value does not contradict the limit.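

In this assay compound 3 gives > 128000 nM, which is a limit and not a number. No step to compound 3 can be read from compound 1 or compound 2, because all three compounds sit at the same limit: the limit of > 128000 nM in this assay, at which 3 of the 3 values shown sit.

The compounds shown leave open whether exchanging chloro for hydrogen, or benzyl for tert-butyl, changes inhibition at all.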